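Thiophen-3-yl for thiophen-2-yl in a ketone-bearing core

The compounds below may be only part of what the source reports. "The series", "measured", "known", "first", "only" and "open" are said of these compounds alone.

Compound 3 `CCCC(=O)C1=C(C)NC(=O)NC1c1cccs1` has the lowest number of the three measured compounds in an assay on membranes from CHO cells for displacement of a labelled ligand from adenosine receptor A1 (Homo sapiens), read by scintillation counting, with a stated time of 60 min, tested at 1 uM; a lower number here means less inhibition, a higher number more inhibition at the concentration tested (going by the name of the read-out). Compound 3 gives 2%, while compound 1 `CCCOC(=O)C1=C(C)NC(=O)NC1c1ccsc1` gives 44% and compound 2 `CC1=C(C(=O)OC(C)(C)C)C(c2ccsc2)NC(=O)N1` gives 15%. Among the compounds with values here, the only measured step that keeps all else fixed, a number 29 percentage points lower from compound 1 to compound 2 (beyond the scatter), concerns the ester group and does not touch the aromatic ring.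

Compound 4 `CCCC(=O)C1=C(C)NC(=O)NC1c1ccsc1` differs from compound 3 in one place: thiophen-3-yl in place of thiophen-2-yl on a saturated ring carbon. Within the data shown here, no measured pair isolates this exchange, so no step in this assay bears on it directly. What can be said is that the two measured compounds carrying thiophen-3-yl, compound 1 and compound 2, both sit above compound 3, but each of them also carries an ester in place of the propylcarbonyl group, so their values cannot be read as the effect of the ring swap alone.

Given that compound 3 gives 2% and that the thiophen-3-yl compounds show higher numbers, compound 4 is expected to move by a number 10 percentage points higher from compound 3 to compound 4 (within the scatter) in this assay, a modest rise that may or may not clear the scatter. Compound 4 is therefore estimated at 12%, with a range from 0% to 35%.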

Compound 4, a percentage reported as inhibition, at one concentration (the size of the read-out at that concentration, not a potency): 6%
The estimate for compound 4 lay 6 percentage points above the measured number; the range from low to high includes it.
By their numbers in this assay, from the lowest: compounds 3, 4 and 2 (each within the scatter of the next, the first and the last beyond it); then compound 1.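

In this assay, the exchange of thiophen-2-yl for thiophen-3-yl on the saturated ring carbon can now be read directly: a number 4 percentage points higher from compound 3 to compound 4 (within the scatter) shows that, with the propylcarbonyl group in place, this assay does not separate the two thiophene groups. With thiophen-3-yl held fixed, the group on the carbonyl carbon gives a mixed picture: propyl in place of propoxy gives a number 38 percentage points lower from compound 1 to compound 4 (beyond the scatter), whereas propyl in place of tert-butoxy gives a number 9 percentage points lower from compound 2 to compound 4 (within the scatter), so the large step belongs to the propoxy compound alone. No measurement shown here gives a reason for either result.

The compounds shown leave open whether thiophen-2-yl and thiophen-3-yl would also read alike with a propoxy group on the carbonyl carbon, the setting in which compound 1 gives 44%. They also leave open what a phenyl ring on the saturated ring carbon, or an amine or a longer chain on the carbonyl carbon, would give in this assay.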